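This account rests on a few compounds, and the source may have more. Where it says the series, first, only, none or still open, it means among the compounds named here.

Series notes. Compound 1 `O=Cc1ccc(-c2cn3ccnc3c(-c3ccc4ncn(C5CCCCC5)c4c3)n2)cc1` is measured in a functional assay on SF-295 cells (Homo sapiens) for inhibition, read by sulforhodamine B assay, with a stated time of 48 h, tested at 10 uM; on this read-out lower numbers stand for less inhibition and higher numbers for more inhibition at the one concentration tested (going by the name of the read-out); compound 1 gives 23.1%. Compound 2 `c1ccc2c(-c3cn4ccnc4c(-c4ccc5ncn(C6CCCCC6)c5c4)n3)cccc2c1` differs from compound 1 by naphthalen-1-yl in place of 4-formylphenyl on an aromatic carbon, and compound 2 gives 6.34%. The change made a step of a number 16.8 percentage points lower from compound 1 to compound 2 (beyond the scatter). Compound 3 `O=Cc1ccc(-c2cn3ccnc3c(-c3ccc4ncn(Cc5ccccc5)c4c3)n2)cc1` differs from compound 1 by benzyl in place of cyclohexyl on an aromatic nitrogen; compound 3 gives 23.1%, the step being no change at the digits printed from compound 1 to compound 3 (within the scatter), so the two cores are not separated on this read-out.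

Compound 4 `c1ccc(Cn2cnc3ccc(-c4nc(-c5cccc6ccccc56)cn5ccnc45)cc32)cc1` has not yet been measured. It differs from compound 3 by naphthalen-1-yl in place of 4-formylphenyl on an aromatic carbon. The surroundings of the place are described in the same words for both pairs, so this is the same change as the one from compound 1 to compound 2, occurring twice in all among the compounds shown.

The expectation for compound 4 rests on the size of the step of a number 16.8 percentage points lower from compound 1 to compound 2 (beyond the scatter) carried over onto the core of compound 3, which sits level with compound 1. The step from compound 3 to compound 4 is expected to be a number 16.6 percentage points lower from compound 3 to compound 4 (beyond the scatter). For compound 4 in this assay the estimate is 6.5%, with a range from 0% to 18%.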

Compound 4, a percentage reported as inhibition, at one concentration (the size of the read-out at that concentration, not a potency): 8.22%
Beside the measured number, compound 4's estimate is 1.7 percentage points below it; measured number inside the range.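

In this assay the exchange of 4-formylphenyl for naphthalen-1-yl gives a step of a number 14.9 percentage points lower from compound 3 to compound 4 (beyond the scatter) on the benzyl core, and this matches the earlier step: the same change on two cores in this assay, a number 16.8 percentage points lower (beyond the scatter) from compound 1 to compound 2 and a number 14.9 percentage points lower (beyond the scatter) from compound 3 to compound 4, 1.9 percentage points apart, within the scatter of two such steps. The exchange of cyclohexyl for benzyl gives a step of a number 1.9 percentage points higher from compound 2 to compound 4 (within the scatter) with naphthalen-1-yl in place, and this also matches the earlier step: the same change on two cores in this assay, no change at the digits printed (within the scatter) from compound 1 to compound 3 and a number 1.9 percentage points higher (within the scatter) from compound 2 to compound 4, 1.9 percentage points apart, within the scatter of two such steps. Each change therefore carries across the two settings shown, but this rests on a single pair of steps per change at one concentration, and it shows neither how either change behaves on a different core nor why the numbers fall as they do.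

On these data alone, the exchange removes the carbonyl and adds a second aromatic ring at once, so it remains open which of the two goes with the step; a plain phenyl or a 4-carboxyphenyl group at that carbon would bear on this. Also open, as far as these compounds go, is how an amine or a longer alkyl chain on the aromatic nitrogen would compare with cyclohexyl and benzyl.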